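This account rests on a few compounds, and the source may have more. Where it says the series, first, only, none or still open, it means among the compounds named here.

Measured so far in an assay for inhibition of serine/threonine-protein kinase PLK2 (Homo sapiens), read by FRET and Z'-LYTE, with a stated time of 1 h; on this read-out lower numbers stand for stronger inhibition and higher numbers for weaker inhibition:
compound 1 `CC[C@@H]1C(=O)N(C)c2cnc(Nc3ccc(S(=O)(=O)NC)cc3)nc2N1C1CCCC1` gives 3.4 nM
compound 2 `CC[C@@H]1C(=O)N(C)c2cnc(Nc3ccc(S(=O)(=O)Nc4ccccc4)cc3)nc2N1C1CCCC1` gives 54.4 nM
compound 3 `CCCNC(=O)c1ccc2c(ccn2-c2ncc3c(n2)N(C2CCCC2)[C@H](CC)C(=O)N3C)c1` gives 11.4 nM

Compound 3 stands second highest of these three numbers, closer to compound 1 and further from compound 2, both gaps beyond the scatter. Compound 4 `CCNC(=O)c1ccc2c(ccn2-c2ncc3c(n2)N(C2CCCC2)[C@H](CC)C(=O)N3C)c1` differs from compound 3 in one place: hydrogen in place of methyl on a saturated chain carbon, two bonds along the chain from an amide-type nitrogen, that is, propyl to ethyl on the amide-type nitrogen. Among the measured compounds shown here, the only measured step, a 16-fold higher number from compound 1 to compound 2 (1.20 log units; beyond the scatter), concerns a group on a sulfonamide nitrogen and a much larger change, so it bears only loosely here, and no closer comparison exists. Going from propyl to ethyl is expected to leave this assay about unchanged, a step within the scatter, a 1.0-fold lower number from compound 3 to compound 4 (0.02 log units; within the scatter). Compound 4 is therefore estimated at 11 nM, with a range from 5 nM to 25 nM.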

Compound 4, half-maximal inhibitory concentration: 4.88 nM
Compound 4: middle estimate off by 2.3-fold (0.35 log units), on the high side; the whole stated range lies above it.
By their numbers in this assay, from the lowest: compounds 1 and 4 (each within the scatter of the next); then compound 3; then compound 2.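

Going from propyl to ethyl on the amide-type nitrogen in this assay gives a 2.3-fold lower number from compound 3 to compound 4 (0.37 log units; beyond the scatter) and so shows that this chain end is not indifferent to change. Losing a single methyl at this place is enough to move the number beyond the scatter, with the ethyl amide giving the lower number of the pair. Nothing at hand accounts for the shift.

Two chain lengths do not make a trend. As far as these compounds go, how a methyl, a butyl or a cyclopropyl on this nitrogen would compare remains open.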